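The compounds below may be only part of what the source reports. "The series", "measured", "known", "first", "only" and "open" are said of these compounds alone.

Measured so far, each entry a limit of the assay:
- compound 1 `CCN(CC)c1ccc(-c2cccc(OC)c2)nn1`: > 25000 nM
- compound 2 `CCN(CC)c1ccc(-c2cccc(C(F)(F)F)c2)nn1`: > 25000 nM
- compound 3 `CN1CCN(c2ccc(-c3cccc(C(F)(F)F)c3)nn2)CC1`: > 25000 nM

In an ADME assay on cells (Fibroblast, Homo sapiens) for antiproliferative activity, with a stated time of 48 h (on this read-out lower numbers stand for stronger inhibition and higher numbers for weaker inhibition), compound 3 gives > 25000 nM, which is a limit and not a number. Among the measured compounds shown here, it has no readable rank against the other two, as the series so far shows (the limit of > 25000 nM in this assay, at which 3 of the 3 values shown sit).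

Compound 4 `FC(F)(F)c1cccc(-c2ccc(N3CCCC3)nn2)c1` is the next entry, and it differs from compound 3 by pyrrolidin-1-yl in place of 4-methylpiperazin-1-yl on an aromatic carbon. In words, pyrrolidin-1-yl takes the place of 4-methylpiperazin-1-yl on an aromatic carbon, and the trifluoromethyl stays.

For the measured compounds named here, two measured steps bear on this change. The closer one is a step that the two limits leave unreadable from compound 2 to compound 3, since it exchanges one amine group for another at the same place. The other is a step that the two limits leave unreadable from compound 1 to compound 2, which concerns a different substituent. Neither has a readable size, so the data give no measured effect to carry over. For compound 4 the expectation therefore rests on a step that the two limits leave unreadable from compound 2 to compound 3, where the exchange left no readable change in this assay. The expected size is a step that the limit leaves unreadable from compound 3 to compound 4, an estimate with no direction that the data support. Compound 4 is expected at 30000 nM, within an estimated range of 12000 nM to 60000 nM, and it will most likely be reported only as a limit.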

Compound 4, half-maximal inhibitory concentration: > 25000 nM
Compound 4 was reported as a limit; the forecaster's own chance of this, stated with the estimate: 80%; the middle value lies beyond the limit too.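

Compound 4 gives > 25000 nM in this assay, which is a limit of the assay and not a number. No new step can be read from compound 3 or compound 2 to compound 4, since all of these compounds sit at the same limit: the limit of > 25000 nM in this assay, at which 4 of the 4 values shown sit. In this assay the compounds shown leave open which change to the shared core, if any, would give a measurable value.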